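Swapping a Cyclohexyl for a Heptyl Chain

This account rests on a few compounds, and the source may have more. Where it says the series, first, only, none or still open, it means among the compounds named here.

Compound 1, `[O-][n+]1nc(NCOC2CCCCC2)[n+]([O-])c2ccccc21`: 4390 nM
Compound 2, `CCOCNc1n[n+]([O-])c2ccccc2[n+]1[O-]`: 2800 nM
Compound 3, `CC(OCNc1n[n+]([O-])c2ccccc2[n+]1[O-])c1ccccc1`: 2510 nM

These three compounds share one core and differ only in the group sitting on an oxygen on a saturated carbon; all were tested in a functional assay on KB cells (Homo sapiens) for cytotoxicity, read by MTT assay, with a stated time of 72 h; a higher number here means a weaker inhibitor, a lower number a stronger inhibitor. Compound 1 gives the highest of the three numbers, though its gaps to compound 2 and compound 3 both lie within the usual scatter. Compound 4, `CCCCCCCOCNc1n[n+]([O-])c2ccccc2[n+]1[O-]`, is not yet measured; it differs from compound 1 by heptyl in place of cyclohexyl on an oxygen on a saturated carbon. The step most like it is a 1.6-fold lower number from compound 1 to compound 2 (0.20 log units; within the scatter), ethyl in place of cyclohexyl, which stayed within the scatter; a 1.1-fold lower number from compound 2 to compound 3 (0.05 log units; within the scatter) likewise changed little. A heptyl chain is therefore expected to move the number little, if at all. For compound 4 the expected value in this assay is 3200 nM, ranging from 1500 nM to 7000 nM, which is expected to mean a 1.4-fold lower number from compound 1 to compound 4 (0.14 log units; within the scatter).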

Compound 4, half-maximal inhibitory concentration: 2520 nM
Compound 4: the middle estimate sits 1.3-fold (0.10 log units) above what was measured; the measured number falls inside the stated range.
By their numbers in this assay, from the lowest: compounds 3, 4, 2 and 1 (each within the scatter of the next).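

In this assay, replacing the ring with an open chain barely registers: heptyl in place of cyclohexyl gives a 1.7-fold lower number from compound 1 to compound 4 (0.24 log units; within the scatter), and lengthening the ethyl of compound 2 to heptyl gives a 1.1-fold lower number from compound 2 to compound 4 (0.05 log units; within the scatter). On this oxygen on a saturated carbon, a long open chain therefore now sits level with a ring, a short chain and a phenyl-bearing group. Nothing available explains this flat response. Still open, going by these compounds, is whether an amine or a carboxylic acid on this chain, or a chain longer than heptyl, would move the number beyond the scatter.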